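This account rests on a few compounds, and the source may have more. Where it says the series, first, only, none or still open, it means among the compounds named here.

Three compounds with one measurement each set the scene. Compound 1, `Cc1ccc(Nc2ncc3c(n2)N(C)C(=O)N(c2cc(NC(=O)c4cccc(C(F)(F)F)c4)ccc2C)C3)cc1C`, gives 17 nM in a functional assay on K562 cells (Homo sapiens) for antiproliferative activity, read by CellTiter-Glo and CCK-8 assay, with a stated time of 72 h; on this read-out higher numbers stand for weaker inhibition of growth and lower numbers for stronger inhibition of growth. Compound 2, `Cc1ccc(NC(=O)c2cccc(C(F)(F)F)c2)cc1N1Cc2cnc(OC3CCN(C(=O)OC(C)(C)C)CC3)nc2N(C)C1=O`, gives 29 nM in this assay. Compound 3, `CNc1nc(Nc2ccc(C)c([N+](=O)[O-])c2)ncc1C(=O)Nc1cc(NC(=O)c2cccc(OC)c2)ccc1C`, gives 480 nM in this assay, the highest of the three numbers, and both other values lie beyond the scatter from it, with compound 2 nearer and compound 1 further away. Compound 3 is built on a different shared core from compounds 1 and 2, so nothing measured here separates the contribution of that core from the contribution of the outer amide.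

Compound 4, `CNc1nc(Nc2ccc(C)c([N+](=O)[O-])c2)ncc1C(=O)Nc1cc(NC(=O)c2ccc3c(c2)OCCO3)ccc1C`, has not been measured. It differs from compound 3 in one place: 2,3-dihydro-1,4-benzodioxin-6-yl in place of 3-methoxyphenyl on a carbonyl carbon. Among the measured compounds shown here, no measured pair shows this exchange, and no measured pair shows any single change at all, so the size and direction of the step rest on nothing but the closeness of the two groups. The exchange keeps the aromatic ring and adds a second ring fused to it, and the expectation for compound 4 is a step of a 1.0-fold higher number from compound 3 to compound 4 (0.02 log units; within the scatter) in this assay, which is not beyond the scatter in either direction. Compound 4 is therefore estimated at 500 nM in this assay, within a range from 150 nM to 1600 nM.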

Compound 4, concentration for 50% growth inhibition: 320 nM
Compound 4: the middle estimate sits 1.6-fold (0.19 log units) above what was measured; measured number inside the range.
By their numbers in this assay, from the lowest: compounds 1 and 2 (each within the scatter of the next); then compounds 4 and 3 (each within the scatter of the next).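

Among the compounds shown here, this pair gives the first single change: in this assay, placing 2,3-dihydro-1,4-benzodioxin-6-yl in place of 3-methoxyphenyl on a carbonyl carbon gives a 1.5-fold lower number from compound 3 to compound 4 (0.18 log units; within the scatter) and so shows no measurable change at this position. On the core shared by compound 3 and compound 4, this place on the carbonyl carbon therefore accepts a second, non-aromatic ring fused to the aromatic ring, with a second oxygen, without the number leaving the scatter, although this is one exchange and not a rule for the position. No measurement available here bears on why the two groups give numbers this close.

As far as these compounds go, what remains open is whether the ring with the trifluoromethyl group found in compounds 1 and 2 would behave the same way on the core of compound 3, so the contributions of the core and the outer amide still cannot be separated. It is also unknown whether a group of a different kind on this carbonyl carbon, such as a piperazine, a carboxylic acid or a short alkyl chain in place of the aromatic ring, would produce a step beyond the scatter.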